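From methoxy to methylsulfanyl on the aromatic ring

The compounds below may be only part of what the source reports. "The series", "measured", "known", "first", "only" and "open" are said of these compounds alone.

Measured in a functional assay on A549 cells (Homo sapiens) for antiproliferative activity, read by MTT assay; on this read-out higher numbers stand for weaker inhibition and lower numbers for stronger inhibition
- compound 1 (`Cn1c(=O)c(=O)n(C2CCCC2)c2nc(N/N=C/c3ccc(C(F)(F)F)cc3)ncc21`) gives 40600 nM
- compound 2 (`COc1ccc(/C=N/Nc2ncc3c(n2)n(C2CCCC2)c(=O)c(=O)n3C)cc1`) gives > 100000 nM

Compound 2 stands at a limit of the assay (> 100000 nM), not at a number. Compound 3 (`CSc1ccc(/C=N/Nc2ncc3c(n2)n(C2CCCC2)c(=O)c(=O)n3C)cc1`) has methylsulfanyl in place of methoxy on an aromatic carbon. Going by the values given here, the one measured step at this place (an at least 2.4-fold higher number from compound 1 to compound 2 (0.39 log units; beyond the scatter)) is itself bounded by that limit, so it gives no exact size. Compound 1 (40600 nM) shows that a group here can bring a measurable value, so a modest step toward lower numbers is expected in this assay. The expected step is an at least 1.4-fold lower number from compound 2 to compound 3 (0.15 log units; that floor lies within the scatter). For compound 3 the estimated value is 70000 nM, with an expected range from 30000 nM to 130000 nM.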

Compound 3, half-maximal inhibitory concentration: 14100 nM
Compound 3: middle estimate off by 5.0-fold (0.70 log units), on the high side, and the stated range ends above it.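

In this assay, the change from methoxy to methylsulfanyl on this aromatic carbon produces an at least 7.0-fold lower number from compound 2 to compound 3 (0.85 log units; beyond the scatter), so the position responds strongly to this exchange of one atom. Methylsulfanyl also improves on trifluoromethyl, with a 2.9-fold lower number from compound 1 to compound 3 (0.46 log units; beyond the scatter), which shows that the best group so far at this place is neither of the first two. Compound 2 stands at a limit and not at a number, so the first step has no exact size: the limit of > 100000 nM in this assay, at which 1 of the 3 values shown sits.

On these data alone, whether an amine or a longer alkylsulfanyl chain here would bring still lower numbers remains open.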